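Swapping fluoro for methyl on the aryl ring

The compounds below may be only part of what the source reports. "The series", "measured", "known", "first", "only" and "open" are said of these compounds alone.

Measured so far:
compound 1 `COc1ccc(-c2nn(-c3ccccc3)cc2C(=O)NC(=S)Nc2ccc(F)cc2)cc1` — 1430 nM
compound 2 `O=C(NC(=S)Nc1ccc(F)cc1)c1cn(-c2ccccc2)nc1-c1ccc(F)cc1` — 3540 nM

In a functional assay on A549 cells (Homo sapiens) for inhibition, read by CCK-8 assay, with a stated time of 48 h (on this read-out higher numbers stand for weaker inhibition and lower numbers for stronger inhibition), compound 2 gives the highest of the two numbers, with compound 1 giving the nearer, lower value. Compound 3 `Cc1ccc(-c2nn(-c3ccccc3)cc2C(=O)NC(=S)Nc2ccc(F)cc2)cc1` is not yet measured; it differs from compound 2 by methyl in place of fluoro on an aromatic carbon. Among the measured compounds shown here, the only step seen, a 2.5-fold higher number from compound 1 to compound 2 (0.39 log units; beyond the scatter), concerns fluoro replacing methoxy and so touches the same place but not the same group. For the measured compounds named here, with no direct precedent, a small step, likely toward a lower number, is expected: a 1.6-fold lower number from compound 2 to compound 3 (0.21 log units; within the scatter). For compound 3 the estimate is 2200 nM, within 900 nM to 5500 nM.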

Compound 3, half-maximal inhibitory concentration: 3420 nM
For compound 3 the middle estimate is 1.6-fold (0.19 log units) below the measured one; low and high end bracket the measured number.
By their numbers in this assay, from the lowest: compound 1; then compounds 3 and 2 (each within the scatter of the next).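

At this place on the aromatic ring, methyl and fluoro cannot be told apart in this assay (a 1.0-fold lower number from compound 2 to compound 3 (0.01 log units; within the scatter)). Methoxy now stands apart from both groups rather than from fluoro alone, as methyl also gives a higher number (a 2.4-fold higher number from compound 1 to compound 3 (0.38 log units; beyond the scatter)). Nothing available explains why methoxy differs from the other two. The compounds shown leave open how an amine, a hydroxyl or a carboxylic acid would behave at this place. They also leave open whether a longer chain, such as ethoxy, would keep the lower number seen with methoxy.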